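The source may report more compounds than this note shows. Statements on the series, on what has been measured and on what is new or still open speak of the compounds shown alone.

Working notes on the nitrofuran carboxamide series.

In an assay on CHO-K1 cells for activation of DNA damage-inducible transcript 3 protein (Homo sapiens), read by a luciferase reporter (a higher number here means that more compound is needed for the effect, a lower number that less compound is needed), compound 1 `O=C(Nc1ccc(S(=O)(=O)N2CCNCC2)cc1)c1ccc([N+](=O)[O-])o1` gives 26400 nM. Compound 2 `O=C(Nc1ccc(S(=O)(=O)N2CCC(F)CC2)cc1)c1ccc([N+](=O)[O-])o1` gives 600 nM, and compound 3 `O=C(Nc1ccc(S(=O)(=O)N2CCC(Cl)CC2)cc1)c1ccc([N+](=O)[O-])o1` gives 800 nM. The step of a 44-fold lower number from compound 1 to compound 2 (1.64 log units; beyond the scatter) and the step of a 33-fold lower number from compound 1 to compound 3 (1.52 log units; beyond the scatter) are both large, whereas the step of a 1.3-fold higher number from compound 2 to compound 3 (0.12 log units; within the scatter) stays within the scatter. Compound 2 therefore stands lowest of the three numbers in this assay, but compound 3 sits within the scatter of it, so no order between compounds 2 and 3 can be read.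

Compound 4 `CC(C)(C)C1CCN(S(=O)(=O)c2ccc(NC(=O)c3ccc([N+](=O)[O-])o3)cc2)CC1` has not yet been measured in this assay. It differs from compound 2 in one place: tert-butyl in place of fluoro on a saturated ring carbon. Among the compounds with values here, the only measured step that touches this ring carbon is the swap from compound 2 to compound 3, chloro in place of fluoro, which gave no change beyond the scatter. Within the data shown here, no measured compound carries a carbon group at this position, so the move to tert-butyl is not covered by a measured step; the large steps from compound 1 concern the ring nitrogen and not this carbon.

Expectation: for compound 4 a step of a 1.3-fold higher number from compound 2 to compound 4 (0.12 log units; within the scatter) within the scatter of this assay is expected, with a wide range because the step of a 1.3-fold higher number from compound 2 to compound 3 (0.12 log units; within the scatter) is the only guide. The estimate for compound 4 is 800 nM, between 250 nM and 3000 nM.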

Compound 4, concentration for half-maximal activity: 700 nM
Estimate against measurement, compound 4: 1.1-fold (0.06 log units) above; measured number inside the range.
By their numbers in this assay, from the lowest: compounds 2, 4 and 3 (each within the scatter of the next); then compound 1.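

In this assay, the ring carbon three ring bonds from the ring nitrogen now carries a carbon group as well as halogens: a 1.2-fold higher number from compound 2 to compound 4 (0.07 log units; within the scatter) and a 1.1-fold lower number from compound 3 to compound 4 (0.06 log units; within the scatter) both stay within the scatter, so tert-butyl, with 4 heavy atoms, cannot be told apart here from fluoro or chloro, each with 1. The earlier chloro and fluoro pair could not show whether this flat read-out extended beyond halogens, and the large step away from the piperazin-1-yl compound now also appears without any halogen on the ring, with a 38-fold lower number from compound 1 to compound 4 (1.58 log units; beyond the scatter). No measurement at hand explains why this position shows so little response to the change.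

On these data alone, whether the same flat read-out holds for an amine, a carboxylic acid or a longer chain on this ring carbon stays open. The compounds shown also leave open whether a hydroxyl or a second fluoro at this position would move the number beyond the scatter.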